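Shortening a side chain at the assay limit

This account rests on a few compounds, and the source may have more. Where it says the series, first, only, none or still open, it means among the compounds named here.

Measured so far in a functional assay on PC-3 cells (Homo sapiens) for cytotoxicity; on this read-out higher numbers stand for weaker inhibition and lower numbers for stronger inhibition
Compound 1 `Nc1nn(Cc2ccccc2)c2nnc(-c3ccccc3)c(-c3ccccc3)c12` gives > 100000 nM as a limit
Compound 2 `CC(=O)n1nc(N)c2c(-c3ccccc3)c(-c3ccccc3)nnc21` gives > 100000 nM as a limit
Compound 3 `Nc1nn(CCOCCO)c2nnc(-c3ccccc3)c(-c3ccccc3)c12` gives > 100000 nM as a limit

None of these readings is a true number. The shared picture is the limit of > 100000 nM in this assay, at which 3 of the 3 values shown sit, and so no order of potency can be drawn among them. In this assay compound 3 gives > 100000 nM which is a limit of the assay.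

The next structure is compound 4 `Nc1nn(COCCO)c2nnc(-c3ccccc3)c(-c3ccccc3)c12` and its difference from compound 3 is 2-hydroxyethoxy in place of (2-hydroxyethoxy)methyl on a saturated chain carbon bound to an aromatic nitrogen with 2-hydroxyethoxy in place of (2-hydroxyethoxy)methyl on a saturated chain carbon bound to an aromatic nitrogen.

The measured change closest to this one is a step that the two limits leave unreadable from compound 1 to compound 3 and the other two are a step that the two limits leave unreadable from compound 1 to compound 2 and a step that the two limits leave unreadable from compound 2 to compound 3 so none of them offers a size to carry over. What remains is that benzyl, acetyl and 2-(2-hydroxyethoxy)ethyl all end at the same limit, and that compound 3 at > 100000 nM starts from it. No shift beyond the usual scatter is therefore expected in this assay in either direction. The expected change is a number no higher from compound 3 to compound 4 (the limit leaves the size open) and this is an estimate. Compound 4 is estimated at 100000 nM with an expected range from 50000 nM to 200000 nM and the assay will most likely report only a limit.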

Compound 4, half-maximal inhibitory concentration: > 100000 nM
Compound 4 was reported as a limit; the forecaster's own chance of this, stated with the estimate: 85%; the middle value sits exactly at the limit.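

In this assay compound 4 gives > 100000 nM, which is a limit of the assay. The steps to compound 4 from compound 1, compound 2 and compound 3 therefore cannot be read. The compounds shown leave open whether any of these groups on the aromatic nitrogen inhibits more strongly than another, because all share one reading: the limit of > 100000 nM in this assay, at which 4 of the 4 values shown sit.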